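Chloro in Place of Bromo Across Two Cores

The compounds below may be only part of what the source reports. "The series", "measured", "known", "first", "only" and "open" are said of these compounds alone.

Measured so far:
compound 1, `O=C1NC(c2ccc(Br)cc2)CN1S(=O)(=O)c1ccc2c(c1)CCC2`, 33900 nM
compound 2, `O=C1NC(c2ccc(Cl)cc2)CN1S(=O)(=O)c1ccc2c(c1)CCC2`, 86300 nM
compound 3, `O=C1NCC(c2ccc(Br)cc2)N1S(=O)(=O)c1ccc2c(c1)CCC2`, > 237000 nM

These compounds were tested in a functional assay on A549 cells (Homo sapiens) for cytotoxicity; a lower number here means a stronger inhibitor, a higher number a weaker inhibitor. Compound 1 gives 33900 nM in this assay, and compound 2 gives 86300 nM. The two differ in one spot only: chloro in place of bromo on an aromatic carbon. That change produced a 2.5-fold higher number from compound 1 to compound 2 (0.41 log units; beyond the scatter). Compound 3 is built from the same atoms as compound 1, joined differently; how the two cores differ is not broken down here. In this assay compound 3 reaches (the limit of > 237000 nM in this assay, at which 1 of the 3 values shown sits), so only a limit and no number is known for it.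

Compound 4, `O=C1NCC(c2ccc(Cl)cc2)N1S(=O)(=O)c1ccc2c(c1)CCC2`, has not yet been measured in this assay. It stands to compound 3 exactly as compound 2 stands to compound 1, the same change: chloro in place of bromo on an aromatic carbon. Because the earlier instance gave a 2.5-fold higher number from compound 1 to compound 2 (0.41 log units; beyond the scatter), a step of similar size towards a higher number is expected here, a step that the limit leaves unreadable from compound 3 to compound 4. Compound 3 already sits at a limit. Compound 4 is therefore expected most likely to return a limit as well, with an estimated 500000 nM, between 200000 nM and 1500000 nM.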

Compound 4, half-maximal inhibitory concentration: > 265000 nM
Compound 4: no number, only a limit (the forecaster's own chance of this, stated with the estimate: 85%); the middle value does not contradict the limit.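

Compound 3 and compound 4 both return only a limit in this assay, not a number, so the step between them cannot be read. The compounds shown leave open whether chloro in place of bromo changes the number on the core of compound 3 as it does on the core of compound 1.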